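The compounds below may be only part of what the source reports. "The series", "measured", "known", "first", "only" and "open" are said of these compounds alone.

Compound 1 `COc1ccc(-c2cc3ccccc3nc2C=O)cc1` gives > 10000 nM in a functional assay on MCF7 cells (Homo sapiens) for antiproliferative activity, read by XTT assay, with a stated time of 72 h (a higher number here means a weaker inhibitor, a lower number a stronger inhibitor), which is a limit of that assay.
Compound 2 `COc1ccc(C(=O)/C=C/c2nc3ccccc3cc2-c2ccc(OC)cc2)cc1` gives 7380 nM in this assay.
Compound 3 `COc1ccc(-c2cc3ccccc3nc2/C=C/C(=O)c2ccc(OC)c(OC)c2)cc1` gives 6030 nM in this assay.

Compound 2 holds the highest of the two numbers shown in this assay; the nearest is compound 3, and the step of a 1.2-fold lower number from compound 2 to compound 3 (0.09 log units; within the scatter) lies within the scatter. Among the compounds with values here, compound 1 sits at a limit of > 10000 nM in this assay, at which 1 of the 3 values shown sits, and gives no measurable step.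

Compound 4 `COc1ccc(-c2cc3ccccc3nc2/C=C/C(=O)c2ccc(N)cc2)cc1` differs from compound 2 in one place: amino in place of methoxy on an aromatic carbon. Within the data shown here, no measured step makes this exchange. Among the measured compounds shown here, the only measured step, a 1.2-fold lower number from compound 2 to compound 3 (0.09 log units; within the scatter), adds a methoxy elsewhere on the shared core and stays within the scatter, so the two measured numbers on this core are of one size. With nothing pointing either way, the change from methoxy to amino is expected to leave the number within the scatter as well. Compound 4 is therefore estimated at 6000 nM in this assay, with a range from 2500 nM to 15000 nM, corresponding to an expected step of a 1.2-fold lower number from compound 2 to compound 4 (0.09 log units; within the scatter), and with some chance that only a limit is returned.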

Compound 4, half-maximal inhibitory concentration: 6920 nM
For compound 4 the middle estimate is 1.2-fold (0.06 log units) below the measured one; low and high end bracket the measured number.
By their numbers in this assay, from the lowest: compounds 3, 4 and 2 (each within the scatter of the next). At a limit, above all of these: compound 1.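

Amino in place of methoxy on this aromatic carbon, para to a large group, exchanges a group rather than adding one, and in this assay it gives a 1.1-fold lower number from compound 2 to compound 4 (0.03 log units; within the scatter), so the entering hydrogen-bond donor leaves the number unmoved beyond the scatter. The larger exchange of 4-aminophenyl in place of 3,4-dimethoxyphenyl on a carbonyl carbon gives a 1.1-fold higher number from compound 3 to compound 4 (0.06 log units; within the scatter), and all three substitution patterns on this end of the shared core now lie within the scatter of each other. Nothing measured here bears on why the number stays flat across these exchanges.

On these data alone, whether this position can move the number at all remains open, as a carboxylic acid, a dimethylamino group or a longer chain there would show. Also open, as far as these compounds go, is whether an amine in place of the methoxy at the other end of the shared core would take the number beyond the scatter.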